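Replacing a dienyl chain on the shared core: estimating compound 3

This account rests on a few compounds, and the source may have more. Where it says the series, first, only, none or still open, it means among the compounds named here.

Compound 1 `CC(C)=CCC/C(C)=C/COc1cc(=O)n(CCCO)c2c1CC(CC=C(C)C)C(C)(C)C2`: 10.6%
Compound 2 `CC(C)=CCC1Cc2c(OCCCOc3ccc([N+](=O)[O-])cc3)cc(=O)n(CCCO)c2CC1(C)C`: 47.5%

In a functional assay on PANC-1 cells (Homo sapiens) for inhibition, read by MTT assay, with a stated time of 24 h, tested at 10 uM (on this read-out higher numbers stand for more inhibition at the one concentration tested (going by the name of the read-out) and lower numbers for less inhibition), compound 1 stands lowest of the two measured compounds. The nearest number belongs to compound 2, and the step of a number 36.9 percentage points higher from compound 1 to compound 2 (beyond the scatter) is large. Compound 3 `CC(C)=CCC1Cc2c(OC(=O)Nc3cccc(F)c3)cc(=O)n(CCCO)c2CC1(C)C` differs from compound 1 by (3-fluorophenyl)carbamoyl in place of 3,7-dimethylocta-2,6-dien-1-yl on an oxygen on an aromatic ring. Among the compounds with values here, the only measured step that bears on this change is the one from compound 1 to compound 2, in which the same dienyl chain left and an aryl-bearing group entered; that step was large and upward. Compound 3 is therefore expected to rise as well, though the entering group here differs, so compound 3 is estimated at 35% (12% to 58%). This estimate means an expected step of a number 24.4 percentage points higher from compound 1 to compound 3 (beyond the scatter).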

Compound 3, a percentage reported as inhibition, at one concentration (the size of the read-out at that concentration, not a potency): 66.1%
The estimate for compound 3 lay 31.1 percentage points below the measured number; measured number outside the range, above it.
By their numbers in this assay, from the lowest: compound 1; then compound 2; then compound 3.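

In this assay, a second, different replacement of the 3,7-dimethylocta-2,6-dien-1-yl chain on this oxygen also gives a large rise, a number 55.5 percentage points higher from compound 1 to compound 3 (beyond the scatter). The entering (3-fluorophenyl)carbamoyl has as many heavy atoms as the chain that leaves, so this rise comes without a change in that count, while an aromatic ring and a hydrogen-bond donor enter. No measurement on hand accounts for the rise. Going by these compounds, it remains open whether the fluorine or the carbamoyl link carries it, which a phenylcarbamoyl or a 3-fluorobenzoyl group on the same oxygen would help to separate.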